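The source may report more compounds than this note shows. Statements on the series, on what has been measured and on what is new or still open speak of the compounds shown alone.

In a functional assay on HBL-100 cells (Homo sapiens) for antiproliferative activity, read by sulforhodamine B assay, with a stated time of 48 h (on this read-out lower numbers stand for stronger inhibition of growth and higher numbers for weaker inhibition of growth), three compounds have been measured so far. Compound 1 `CCCCCCC(C#CC(=O)O)O/C=C/C(=O)OC` gives > 100000 nM, and this is a limit of the assay, not a number. Compound 2 `CCCCCCC(C#CC(=O)OC)O/C=C/C(=O)OC` gives 2500 nM, and compound 3 `COC(=O)C#CC(O/C=C/C(=O)OC)C(C)(C)C` gives 1800 nM. Tert-butyl in place of hexyl gives a 1.4-fold lower number from compound 2 to compound 3 (0.14 log units; within the scatter), so compound 3 stands level with the only other compound that has a numerical value.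

The next compound to be tested is compound 4 `COC(=O)/C=C/OC(C#CC(=O)O)C(C)(C)C`. It has hydrogen in place of methyl on an oxygen next to a carbonyl group, which turns methoxycarbonyl to carboxy: hydrogen in place of methyl on an oxygen next to a carbonyl group. The measured step that bears most directly on this is the same exchange in the opposite direction, where methyl in place of hydrogen gave an at least 40-fold lower number from compound 1 to compound 2 (1.60 log units; beyond the scatter). That large step rests on a limit, so its true size is not known. The tert-butyl for hexyl exchange, at a 1.4-fold lower number from compound 2 to compound 3 (0.14 log units; within the scatter), gives no sign that the tert-butyl compounds should behave differently. A large step towards a higher number is therefore expected in this assay, and the expected step is a 44-fold higher number from compound 3 to compound 4 (1.65 log units; beyond the scatter). The assay may report only a limit, as it did for compound 1 in the limit of > 100000 nM in this assay, at which 1 of the 3 values shown sits. The estimate for compound 4 is 80000 nM, within an expected range from 20000 nM to 100000 nM.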

Compound 4, concentration for 50% growth inhibition: > 100000 nM
Compound 4: only a limit was reported; the forecaster's own chance of this, stated with the estimate: 60%; at least 1.2-fold (0.09 log units) between middle value and limit.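

In this assay, hydrogen in place of methyl on an oxygen next to a carbonyl group gives an at least 55-fold higher number from compound 3 to compound 4 (1.74 log units; beyond the scatter), and this step too rests on a limit of the assay and not on a number. Until now the loss of this methyl had been seen only with the hexyl chain; it now appears with tert-butyl as well, so the change no longer rests on a single pair, and the two steps can be set side by side: the same change on two cores in this assay, an at least 40-fold lower number (1.60 log units; beyond the scatter) from compound 1 to compound 2 and an at least 55-fold lower number (1.74 log units; beyond the scatter) from compound 4 to compound 3; the limit leaves it open whether they differ Compound 1 and compound 4, the two carboxy compounds, are both limits, so the step between them cannot be read, and the exchange of tert-butyl for hexyl can be read only among the two methyl esters: the limit of > 100000 nM in this assay, at which 2 of the 4 values shown sit.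

What the compounds shown leave open is whether methyl is the only group on this oxygen that gives a measurable number, or whether an ethyl group or a longer chain there would do the same. They also leave open what an amide in place of this ester would give in this assay, and how far above the limit the two carboxylic acids lie.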